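The compounds below may be only part of what the source reports. "The series", "measured", "known", "first", "only" and "open" are said of these compounds alone.

Measured compounds: compound 1 `O=C(O)/C(O)=C/C(=O)c1cn(Cc2ccc(F)cc2)c2ccc(Br)cc2c1=O` gives > 1000000 nM; compound 2 `CCOC(=O)/C(O)=C/C(=O)c1cn(Cc2ccc(F)cc2)c2ccc(OCc3ccc(F)cc3)cc2c1=O` gives > 1000000 nM; compound 3 `CCOC(=O)/C=C/c1ccc2c(c1)c(=O)c(C(=O)/C=C(\O)C(=O)OCC)cn2Cc1ccc(F)cc1` gives > 1000000 nM.

In an ADME assay on TZM cells (Homo sapiens) for cytotoxicity, read by WST assay, with a stated time of 3 days (a higher number here means that more compound is tolerated, a lower number that less compound is tolerated), each of these three values is a limit of the assay and not a number. Compound 1 therefore stands only at that limit, with nothing to rank it against the other two. Among the compounds with values here, the one step between measured neighbours, a step that the two limits leave unreadable from compound 2 to compound 3, is unreadable for the same reason: the limit of > 1000000 nM in this assay, at which 3 of the 3 values shown sit.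

Compound 4 `O=C(O)/C=C/c1ccc2c(c1)c(=O)c(C(=O)/C=C(\O)C(=O)O)cn2Cc1ccc(F)cc1` differs from compound 1 by 2-carboxyethenyl in place of bromo on an aromatic carbon. Within the data shown here, no measured step bears on this change, and the three limits give no direction. Compound 4 is therefore expected to sit at the limit as well, a step of a number no higher from compound 1 to compound 4 (the limit leaves the size open), with an estimate of 1000000 nM and a range from 300000 nM to 3000000 nM.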

Compound 4, half-maximal cytotoxic concentration: > 1000000 nM
Compound 4: only a limit was reported; the forecaster's own chance of this, stated with the estimate: 90%; the middle value sits exactly at the limit.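

The step from compound 1 to compound 4 cannot be read, because both values are limits: the limit of > 1000000 nM in this assay, at which 4 of the 4 values shown sit.

In this assay the compounds shown leave open at what concentration any of them becomes cytotoxic, and whether either substitution changes that concentration.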